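Two Chlorines on the Benzoyl Ring of Compound 1

The compounds below may be only part of what the source reports. "The series", "measured", "known", "first", "only" and "open" are said of these compounds alone.

Measured so far:
compound 1 `O=C(Nc1c(C(O)(C(F)(F)F)C(F)(F)F)ccc2ccccc12)c1ccccc1` gives 44 nM
compound 2 `O=C(Nc1c(C(O)(C(F)(F)F)C(F)(F)F)ccc2ccccc12)c1ccccc1Cl` gives 2040 nM
compound 3 `O=C(Nc1c(C(O)(C(F)(F)F)C(F)(F)F)ccc2ccccc12)c1ccc(Cl)cc1` gives 570 nM

In an assay on LtK cells with ATP-sensitive inward rectifier potassium channel 11 (Homo sapiens) as the target (on this read-out lower numbers stand for an effect already at smaller amounts and higher numbers for an effect only at larger amounts of compound), compound 1 stands lowest of the three numbers shown; the nearest is compound 3 and the furthest is compound 2, both beyond the scatter. Compound 4 `O=C(Nc1c(C(O)(C(F)(F)F)C(F)(F)F)ccc2ccccc12)c1cc(Cl)cc(Cl)c1` is not yet measured. Its change from compound 1 is 3,5-dichlorophenyl in place of phenyl on a carbonyl carbon.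

Within the data shown here, two measured steps bear on this: chloro in place of hydrogen on an aromatic carbon gave a 46-fold higher number from compound 1 to compound 2 (1.67 log units; beyond the scatter) and, at the other position, a 13-fold higher number from compound 1 to compound 3 (1.11 log units; beyond the scatter). Both single chlorines pushed the number up strongly. Among the measured compounds shown here, no measured compound carries a chlorine at either position used in compound 4, and none carries two chlorines, so the precedent is indirect. Still, with both measured chlorines acting in the same direction, compound 4 is expected to show a large step upward in this assay, estimated as a 20-fold higher number from compound 1 to compound 4 (1.31 log units; beyond the scatter). Compound 4 is therefore estimated at 900 nM, with a range from 200 nM to 4000 nM.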

Compound 4, half-maximal effective concentration: 306 nM
Compound 4: middle estimate off by 2.9-fold (0.47 log units), on the high side, and the stated range covers the measured number.
By their numbers in this assay, from the lowest: compound 1; then compounds 4 and 3 (each within the scatter of the next); then compound 2.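

In this assay, the 3,5-dichlorophenyl group still costs ground against the plain phenyl, with a 7.0-fold higher number from compound 1 to compound 4 (0.84 log units; beyond the scatter), so all three chlorine patterns shown on this ring give a higher number than compound 1. The number of chlorines does not set the size of the cost, since two chlorines here compare well with the single chlorine of the 2-chlorophenyl group, with a 6.7-fold lower number from compound 2 to compound 4 (0.82 log units; beyond the scatter). Against the 4-chlorophenyl group, there is a 1.9-fold lower number from compound 3 to compound 4 (0.27 log units; within the scatter), so a second chlorine in this arrangement cannot be told apart from that single chlorine. No measurement here accounts for these differences.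

The compounds shown leave open whether a group other than chlorine on this ring, such as a methyl, a methoxy or an amine, could match compound 1. They also leave open what a carboxylic acid or a longer chain would do in place of the phenyl.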